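Methyl on the Ring Oxygen: a Large Step Repeated

The source may report more compounds than this note shows. Statements on the series, on what has been measured and on what is new or still open speak of the compounds shown alone.

Compound 1 `O=C(Nc1cccc(-n2cc(-c3ccncc3)c(-c3cc(O)cc(Cl)c3)n2)c1)Nc1ccc(Cl)c(C(F)(F)F)c1` and compound 2 `COc1cc(Cl)cc(-c2nn(-c3cccc(NC(=O)Nc4ccc(Cl)c(C(F)(F)F)c4)c3)cc2-c2ccncc2)c1` share one core, and compound 3 `O=C(Nc1cccc(-n2cc(-c3ccncc3)c(-c3cc(O)cc(Cl)c3)n2)c1)c1cc(C(F)(F)F)cc(C(F)(F)F)c1` and compound 4 `COc1cc(Cl)cc(-c2nn(-c3cccc(NC(=O)c4cc(C(F)(F)F)cc(C(F)(F)F)c4)c3)cc2-c2ccncc2)c1` share another. In a functional assay on COLO 205 cells (Homo sapiens) for inhibition, read by sulforhodamine B assay, with a stated time of 48 h, tested at 10 uM (on this read-out lower numbers stand for a stronger effect and higher numbers for a weaker effect at the one concentration tested), compound 1 gives 63.4%. Compound 2 differs from compound 1 by methyl in place of hydrogen on an oxygen on an aromatic ring. In this assay compound 2 gives -48.3%, so the step of a number 111.7 percentage points lower from compound 1 to compound 2 (beyond the scatter) is a large drop. Compound 3 gives 38.7% in this assay. How the core of compound 3 differs from that of compound 1 is not broken down here. Compound 4 has not been measured; it differs from compound 3 by methyl in place of hydrogen on an oxygen on an aromatic ring, at the same place as before, so this is the same change. The earlier step was large and clearly beyond the scatter, and compound 3 starts from a lower number than compound 1, so a step of similar direction but uncertain size is expected: a number 78.7 percentage points lower from compound 3 to compound 4 (beyond the scatter). On that basis compound 4 is estimated at -40% in this assay, expected to lie between -90% and 20%.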

Compound 4, a percentage reported as activity, at one concentration (the size of the read-out at that concentration, not a potency): 88.7%
Estimate against measurement, compound 4: 128.7 percentage points below; measured number above the stated range.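

In this assay, the change from hydroxy to methoxy on the 3-chloro-5-hydroxyphenyl group does not carry over from one core to the other, since the new step is a number 50 percentage points higher from compound 3 to compound 4 (beyond the scatter), which means a weaker effect, whereas the same change on the first core gave a stronger one. Set side by side, the two steps run in opposite directions and differ clearly: the same change on two cores in this assay, a number 111.7 percentage points lower (beyond the scatter) from compound 1 to compound 2 and a number 50 percentage points higher (beyond the scatter) from compound 3 to compound 4, 161.7 percentage points apart, beyond the scatter of two such steps With only one pair on each core, this shows that the outcome of the change depends on the core it is made on, but it does not show which part of the core decides the outcome, or what the change would do on a third core.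

Only hydrogen and methyl appear on this oxygen in the compounds shown. Going by these compounds, it remains open whether an ethyl group or a longer chain there, or an amine in place of the hydroxy group, would follow the direction seen on either core.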